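A few compounds are considered here, and "the series" means these few. Any claim that something is new, unique, unknown or untested is made for them only; others in the source may bear on it.

Measured so far, in a functional assay on liver (Sus scrofa) for inhibition of squalene monooxygenase (Homo sapiens), using microsomes; a lower number here means a stronger inhibitor, a higher number a weaker inhibitor:

- compound 1 `CCN(C/C=C/C#CC(C)(C)C)Cc1cccc(OC[Si](C)(C)c2ccc(C)cc2)c1` gives 120 nM
- compound 2 `CCN(C/C=C/C#CC(C)(C)C)Cc1cccc(OC[Si](C)(C)c2ccc(C(=O)C(F)(F)F)cc2)c1` gives 5000 nM
- compound 3 `C=Cc1ccc([Si](C)(C)COc2cccc(CN(CC)C/C=C/C#CC(C)(C)C)c2)cc1` gives 70 nM

Compound 1 stands second highest of the three numbers: compound 3 lies close to it, while compound 2 is far weaker. The two measured steps from compound 1 both change a group on an aromatic carbon of the ring attached to silicon: a 42-fold higher number from compound 1 to compound 2 (1.62 log units; beyond the scatter), a large loss, whereas a 1.7-fold lower number from compound 1 to compound 3 (0.23 log units; within the scatter), a change that stays within the scatter. Between the two, a 71-fold lower number from compound 2 to compound 3 (1.85 log units; beyond the scatter).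

Compound 4 `CCN(C/C=C/C#CC(C)(C)C)Cc1cccc(OC[Si](C)(C)c2ccccc2-c2ccsc2)c1` takes a different route from compound 1: 2-(thiophen-3-yl)phenyl in place of 4-methylphenyl on a silicon. Among the compounds with values here, this exchanges the whole aryl group on silicon rather than a single substituent, so none of the measured steps matches it. What they do show is that this ring can carry a vinyl group without a change beyond the scatter, while a (trifluoromethyl)carbonyl group costs much. A larger, two-ring group is outside that experience, so the expected step is uncertain in direction and judged moderate, most likely a small weakening. The expected step is a 2.5-fold higher number from compound 1 to compound 4 (0.40 log units; beyond the scatter). Compound 4 is expected to give 300 nM, with a likely range from 60 nM to 1500 nM.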

Compound 4, half-maximal inhibitory concentration: 10000 nM
Compound 4: the middle estimate sits 33-fold (1.52 log units) below what was measured, outside the stated range (above it).
By their numbers in this assay, from the lowest: compounds 3 and 1 (each within the scatter of the next); then compounds 2 and 4 (each within the scatter of the next).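

In this assay, the group on silicon proves far less forgiving than compound 3 suggested: 2-(thiophen-3-yl)phenyl in place of 4-methylphenyl gives an 83-fold higher number from compound 1 to compound 4 (1.92 log units; beyond the scatter), and in place of 4-vinylphenyl it gives a 140-fold higher number from compound 3 to compound 4 (2.15 log units; beyond the scatter), both large losses. Until now only the (trifluoromethyl)carbonyl group had cost this much, yet a very different group now lands level with it, a 2.0-fold higher number from compound 2 to compound 4 (0.30 log units; within the scatter), a step within the scatter, so a large loss at this position is not tied to that one substituent. Nothing measured here accounts for either loss, so the data show how much is lost at this position but not the reason.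

Compound 4 changes two things at once compared with compound 1, the added thiophen-3-yl ring and where the substituent sits on the phenyl, and the compounds shown leave open which of these goes with the loss. A 2-methylphenyl or a 4-(thiophen-3-yl)phenyl on the same silicon would begin to separate the two.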